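The source may report more compounds than this note shows. Statements on the series, on what has been measured and on what is new or still open speak of the compounds shown alone.

Working notes on the series, all read in a functional assay on HCT-116 cells (Homo sapiens) for inhibition, read by MTT assay, with a stated time of 72 h; a lower number here means a stronger inhibitor of growth, a higher number a weaker inhibitor of growth. Compound 1 (`COc1ccc(-c2nc3c(N4CCN(Cc5cc(C)on5)CC4)c(Br)cnc3[nH]2)cc1`) gives 540 nM, compound 2 (`Cc1cc(CN2CCN(c3c(Br)cnc4[nH]c(-c5ccc(CN(C)C)cc5)nc34)CC2)no1`) gives 230 nM, and compound 3 (`CN(C)c1ccc(-c2nc3c(N4CCN(Cc5ccncc5)CC4)c(Br)cnc3[nH]2)cc1`) gives 700 nM. Compound 2 holds the lowest number of the three, and its gaps to compound 1 and to compound 3 both lie beyond the scatter.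

Compound 4 (`Cc1cc(CN2CCN(c3c(Br)cnc4[nH]c(-c5ccc(OCCO)cc5)nc34)CC2)no1`) has not yet been measured. Its difference from compound 2 is 2-hydroxyethoxy in place of (dimethylamino)methyl on an aromatic carbon, para to a large group.

Going by the values given here, one measured step bears on this change: a 2.3-fold lower number from compound 1 to compound 2 (0.37 log units; beyond the scatter), a modest step that brought in the same (dimethylamino)methyl in place of methoxy. Compound 4 gives that group up again, and an oxygen-linked group takes its place, as in compound 1 at 540 nM. A modest move back to a higher number in this assay is therefore expected. Among the compounds with values here, no measured compound carries 2-hydroxyethoxy, so this reading rests on a single step and the range stays wide.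

The expected change is a 2.2-fold higher number from compound 2 to compound 4 (0.34 log units; beyond the scatter). For compound 4 the estimate is 500 nM, with an expected range of 220 nM to 1100 nM.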

Compound 4, concentration for 50% growth inhibition: 280 nM
For compound 4 the middle estimate is 1.8-fold (0.25 log units) above the measured one, and the stated range covers the measured number.
By their numbers in this assay, from the lowest: compounds 2, 4, 1 and 3 (each within the scatter of the next, the first and the last beyond it).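

At this aromatic carbon, para to a large group, the exchange of (dimethylamino)methyl for 2-hydroxyethoxy gives a 1.2-fold higher number from compound 2 to compound 4 (0.09 log units; within the scatter) in this assay, so giving up (dimethylamino)methyl does not in itself bring a step beyond the scatter. On the oxygen-linked side, the added hydroxymethyl gives a 1.9-fold lower number from compound 1 to compound 4 (0.29 log units; within the scatter), which leaves compound 4 inseparable from both neighbours even though those two stand apart by a 2.3-fold lower number from compound 1 to compound 2 (0.37 log units; beyond the scatter). An oxygen link at this place therefore does not by itself tie the number to that of compound 1, and the earlier single step cannot be read as a general contrast between oxygen-linked groups and (dimethylamino)methyl. Nothing available explains these steps.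

Still open, on these data alone, is whether a longer chain ending in a hydroxyl, a carboxylic acid or a cyclic amine at this position would separate from compound 2 beyond the scatter. Also open, as far as these compounds go, is whether the same exchange would read alike on the background of compound 3, which shares the core but carries a different group at the other end.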